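Replacing the Arylamino Group at the Carbonyl

The compounds below may be only part of what the source reports. "The series", "measured", "known", "first", "only" and "open" are said of these compounds alone.

Compound 1 `COc1cc(-c2nn(-c3cccc(NC(=O)Nc4cccc(C(F)(F)F)c4)c3)cc2-c2ccncc2)ccc1Cl`: 1870 nM
Compound 2 `COc1cc(-c2nn(-c3cccc(NC(=O)Nc4ccc(Cl)c(C(F)(F)F)c4)c3)cc2-c2ccncc2)ccc1Cl`: 4450 nM

In a functional assay on HT-29 cells (Homo sapiens) for inhibition, read by sulforhodamine B assay, with a stated time of 48 h (a higher number here means a weaker inhibitor of growth, a lower number a stronger inhibitor of growth), compound 2 gives the higher of the two numbers, so on these data it is the weaker inhibitor of growth. For the measured compounds named here, the only measured step is a 2.4-fold higher number from compound 1 to compound 2 (0.38 log units; beyond the scatter), a modest shift from adding chloro on an aromatic carbon. Compound 3 `COc1cc(-c2nn(-c3cccc(NC(=O)c4ccccc4)c3)cc2-c2ccncc2)ccc1Cl` differs from compound 2 by phenyl in place of (4-chloro-3-(trifluoromethyl)phenyl)amino on a carbonyl carbon. Going by the values given here, the one measured step changes a substituent on the outer aromatic ring and leaves the carbonyl side untouched, so it does not bear directly on this change; no measured pair shows what removing the whole arylamino group does. The expectation therefore rests only on the fact that both measured compounds carry that arylamino group and both inhibit in the low micromolar range, and on the size of the change itself. For compound 3 the expected outcome is a 2.0-fold higher number from compound 2 to compound 3 (0.31 log units; beyond the scatter), with a wide range. The estimate for compound 3 in this assay is 9000 nM, between 2000 nM and 40000 nM.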

Compound 3, concentration for total growth inhibition: > 100000 nM
Compound 3: a limit, no number (the forecaster's own chance of this, stated with the estimate: 20%); middle value at least 11-fold (1.04 log units) from the limit.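

In this assay the reading for compound 3 is a limit and not a number: the limit of > 100000 nM in this assay, at which 1 of the 3 values shown sits. Even so, putting phenyl on the carbonyl carbon gives an at least 22-fold higher number from compound 2 to compound 3 (1.35 log units; beyond the scatter), and the same kind of replacement gives an at least 53-fold higher number from compound 1 to compound 3 (1.72 log units; beyond the scatter); both are far larger than a 2.4-fold higher number from compound 1 to compound 2 (0.38 log units; beyond the scatter), which came from changing only a substituent on the outer ring. The earlier pair showed that this substituent tunes growth inhibition modestly, whereas these steps show that growth inhibition in this series depends heavily on the arylamino group as a whole.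

The replacement removes the amino nitrogen with its hydrogen and the substituted ring's chloro and trifluoromethyl groups in a single change, so the compounds shown cannot say which of these parts matters. A plain phenylamino group on the carbonyl carbon would begin to separate them.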